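Pyrrolidin-1-yl to Dimethylamino on the Carbonyl Carbon

The source may report more compounds than this note shows. Statements on the series, on what has been measured and on what is new or still open speak of the compounds shown alone.

Measured compounds:
compound 1 `C[C@@H]1N[C@H](C(=O)N2CCC[C@H]2C#N)C[C@@H]1C(=O)N1CCCC1`: 94%
compound 2 `N#C[C@@H]1CCCN1C(=O)[C@@H]1CCCN1`: 20%
compound 3 `CNC(=O)[C@@H]1CN[C@H](C(=O)N2CCC[C@H]2C#N)C1`: 75%

In an assay on the whole organism (plasma, strain Sprague-Dawley) for inhibition of Dipeptidyl peptidase 4 (Rattus norvegicus), with a stated time of 6 h, at a dose of 1 mg/kg by the oral route (a lower number here means less inhibition, a higher number more inhibition at the dose given (going by the name of the read-out)), compound 1 gives 94%, the highest of the three numbers; compound 3 stands nearest with 75% and compound 2 furthest with 20%. Among the measured compounds shown here, the one step between compounds differing in a single place is a number 55 percentage points higher from compound 2 to compound 3 (beyond the scatter), which shows that an amide on the saturated ring carbon carries much of the read-out. Compound 4 `C[C@@H]1N[C@H](C(=O)N2CCC[C@H]2C#N)C[C@@H]1C(=O)N(C)C` differs from compound 1 only by dimethylamino in place of pyrrolidin-1-yl on a carbonyl carbon. For the measured compounds named here, no measured step exchanges one amide substituent for another; compound 1 and compound 3, which carry different amides and also differ elsewhere, are both high. The change therefore keeps a tertiary amide in place, and a step of small size, if any, is expected in this assay. Compound 4 is expected to give 88% (range 74% to 96%), a step of a number 6 percentage points lower from compound 1 to compound 4 (within the scatter) that is expected to fall within the scatter.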

Compound 4, a percentage reported as inhibition, in the whole organism at one dose (the size of the read-out at that dose, not a potency): 95%
Beside the measured number, compound 4's estimate is 7 percentage points below it; low and high end bracket the measured number.
By their numbers in this assay, from the lowest: compound 2; then compound 3; then compounds 1 and 4 (each within the scatter of the next).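

In this assay, among the compounds shown here, the exchange of pyrrolidin-1-yl for dimethylamino on the carbonyl carbon gives a number 1 percentage points higher from compound 1 to compound 4 (within the scatter), the first direct reading of one tertiary amide substituent against another at this position. The ring of pyrrolidin-1-yl is therefore not required to hold the read-out in this pair, since dimethylamino, with no ring and fewer heavy atoms, gives a number within the scatter of it. No measured property is available to bear on why the two groups read alike.

Compound 1 at 94% and compound 4 at 95% both stand high on a read-out taken at a single dose, so any difference in potency between them could stay hidden. From the compounds shown here alone, whether morpholin-4-yl, or a hydroxyl forming a carboxylic acid, on the same carbonyl carbon would hold the read-out remains open.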